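Amine swap on the shared core: compound 3 to compound 4

The source may report more compounds than this note shows. Statements on the series, on what has been measured and on what is new or still open speak of the compounds shown alone.

Three members of the series have been run in a functional assay on L02 cells (Homo sapiens) for inhibition, read by Griess assay, with stated times of 1 h and 24 h (on this read-out higher numbers stand for weaker inhibition and lower numbers for stronger inhibition), so far. Compound 1 `CCCCNc1nc(/C=C/c2ccccc2)nc2ccsc12` gives > 1000000 nM and this is a limit of the assay rather than a number. Compound 2 `Fc1ccc(CNc2nc(/C=C/c3ccccc3)nc3ccsc23)cc1` gives > 1000000 nM and this too is a limit. Compound 3 `CCN1CCN(c2nc(/C=C/c3cc(OC)c(OC)c(OC)c3)nc3ccsc23)CC1` gives > 1000000 nM and this again is a limit. On the numbers shown compound 3 therefore stands exactly where the whole series stands so far: at the limit of > 1000000 nM in this assay, at which 3 of the 3 values shown sit, and nothing separates it from compound 1 or from compound 2.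

Among the measured compounds shown here, the only step measured in one place is a step that the two limits leave unreadable from compound 1 to compound 2 with 4-fluorophenyl in place of propyl on a saturated chain carbon bound to a nitrogen on an aromatic ring; the two limits leave its size unreadable.

Compound 4 `COc1cc(/C=C/c2nc(NC(C)C)c3sccc3n2)cc(OC)c1OC` is the next entry for this assay. It differs from compound 3 in one place: isopropylamino in place of 4-ethylpiperazin-1-yl on an aromatic carbon. For the measured compounds named here, no measured step covers this change, and the one measured step gives no readable size. The expectation therefore rests on the limit of compound 3 alone, so the expected step of a number no higher from compound 3 to compound 4 (the limit leaves the size open) is none beyond the scatter, with a further limit the likeliest outcome. Compound 4 is accordingly estimated at 1000000 nM with a range from 300000 nM to 3000000 nM.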

Compound 4, half-maximal inhibitory concentration: > 1000000 nM
Compound 4 ended at the assay's limit; the forecaster's own chance of this, stated with the estimate: 85%; the middle value lies on the limit itself.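

Between compound 3 and compound 4 no step can be read, since the isopropylamino and 4-ethylpiperazin-1-yl analogues both end at a limit in this assay: the limit of > 1000000 nM in this assay, at which 4 of the 4 values shown sit.

The compounds shown leave open whether any change on the shared core gives a readable number in this assay, and how large any step between these compounds would be.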